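This account rests on a few compounds, and the source may have more. Where it says the series, first, only, none or still open, it means among the compounds named here.

Within the data shown here, compound 1 `Cc1cnc(Nc2ccc(C(C)C)cc2)nc1Nc1nc2ccccc2s1` is one of three compounds measured in a functional assay on HCT-116 cells (Homo sapiens) for antiproliferative activity, read by MTT assay, with a stated time of 48 h; on this read-out higher numbers stand for weaker inhibition and lower numbers for stronger inhibition. In this assay compound 1 gives > 50000 nM, which is a limit of the assay rather than a number, (the limit of > 50000 nM in this assay, at which 1 of the 3 values shown sits). Two related compounds carry a sulfonamide instead: compound 2 `Cc1ccc2nc(Nc3nc(Nc4ccc(S(N)(=O)=O)cc4)ncc3C)sc2c1` and compound 3 `NS(=O)(=O)c1ccc(Nc2ncc(F)c(Nc3nc4ccccc4s3)n2)cc1`. In this assay compound 2 gives 3870 nM, and compound 3 gives 3260 nM; those two values lie within the scatter of each other. Compound 4 `Cc1cnc(Nc2ccc([N+](=O)[O-])cc2)nc1Nc1nc2ccccc2s1` is not yet measured. It differs from compound 1 by nitro in place of isopropyl on an aromatic carbon. Among the measured compounds shown here, no measured pair shows this change, so its size is open. The estimate for compound 4 is 15000 nM, between 3000 nM and 60000 nM. The expected step is an at least 3.3-fold lower number from compound 1 to compound 4 (0.52 log units; beyond the scatter).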

Compound 4, half-maximal inhibitory concentration: 6330 nM
The estimate for compound 4 lay 2.4-fold (0.37 log units) above the measured number; measured number inside the range.
By their numbers in this assay, from the lowest: compounds 3, 2 and 4 (each within the scatter of the next). At a limit, above all of these: compound 1.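

In this assay, replacing 4-isopropylphenyl with 4-nitrophenyl gives an at least 7.8-fold lower number from compound 1 to compound 4 (0.89 log units; beyond the scatter), so the group at this place on the shared core does change the read-out. Compound 1 stands at a limit of the assay, not at a number, and the true size of the step stays unknown because of that limit: the limit of > 50000 nM in this assay, at which 1 of the 4 values shown sits.

From the compounds shown here alone, what an amine or a carboxylic acid would do at this same place remains open. So does whether the change from isopropyl to nitro would give a similar step on a different core.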